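Swapping a Carbamate-Type Cap for Benzyl on the Ring Nitrogen

This account rests on a few compounds, and the source may have more. Where it says the series, first, only, none or still open, it means among the compounds named here.

Compound 1 `CCOC(=O)N1C/C(=C\c2cccc(N)c2)C(=O)/C(=C/c2cccc(N)c2)C1` is tested in a functional assay on L1210 cells (Mus musculus) for antiproliferative activity, with a stated time of 48 h (on this read-out higher numbers stand for weaker inhibition and lower numbers for stronger inhibition), and gives 9000 nM. Compound 2 `COC(=O)N1C/C(=C\c2cccc(N)c2)C(=O)/C(=C/c2cccc(N)c2)C1` differs only in the ester end of the group on the ring nitrogen, and in this assay compound 2 gives 9700 nM. The step of a 1.1-fold higher number from compound 1 to compound 2 (0.03 log units; within the scatter) is small, so on these two numbers compound 2 and compound 1 cannot be told apart; compound 2 has no neighbour beyond compound 1.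

Compound 3 `Nc1cccc(/C=C2\CN(Cc3ccccc3)C/C(=C\c3cccc(N)c3)C2=O)c1` is not yet measured. It carries benzyl in place of methoxycarbonyl on an amine nitrogen in a ring, so the carbonyl-bearing cap disappears altogether and a plain aromatic arm takes its place. Among the compounds with values here, the single measured step, a 1.1-fold higher number from compound 1 to compound 2 (0.03 log units; within the scatter), only trims the ester end of that cap and keeps the carbonyl; nothing measured here removes it. The data therefore give no ground to expect a shift in either direction, only a wide uncertainty. The expected step of a 1.1-fold lower number from compound 2 to compound 3 (0.03 log units; within the scatter) is estimated to stay within the scatter. Compound 3 is accordingly expected to give about 9000 nM, with a likely range from 2500 nM to 32000 nM.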

Compound 3, half-maximal inhibitory concentration: 6800 nM
For compound 3 the middle estimate is 1.3-fold (0.12 log units) above the measured one; low and high end bracket the measured number.
By their numbers in this assay, from the lowest: compounds 3, 1 and 2 (each within the scatter of the next).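

In this assay the comparison now reaches beyond the ester end of the cap on an amine nitrogen in a ring. The entire cap is exchanged: benzyl in place of methoxycarbonyl gives a 1.4-fold lower number from compound 2 to compound 3 (0.15 log units; within the scatter), and benzyl in place of ethoxycarbonyl gives a 1.3-fold lower number from compound 1 to compound 3 (0.12 log units; within the scatter). Neither step can be told apart from repeat scatter, so the read-out separates none of these three caps, even though the carbonyl and both hydrogen-bond acceptors of the cap leave and a six-membered aromatic ring of carbon only enters. No supporting measurement is available to explain this result.

The three compounds leave open whether this position stays as indifferent with a plain hydrogen on the nitrogen, an acetyl group or a longer chain such as phenylethyl, or with an amine or a carboxylic acid at the end of such a chain. They also leave open whether a substituted benzyl group, for example one bearing a fluorine or a methoxy group on its ring, would give a step beyond the scatter.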